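From benzothiophene to thiophene on the piperidine methyl

The compounds below may be only part of what the source reports. "The series", "measured", "known", "first", "only" and "open" are said of these compounds alone.

Compound 2 `c1ccc(C(OCCC2CCN(Cc3cc4ccccc4s3)CC2)c2ccccc2)cc1` gives 172 nM in an assay on cell membranes for binding affinity to sodium-dependent dopamine transporter (Rattus norvegicus) (on this read-out higher numbers stand for weaker inhibition and lower numbers for stronger inhibition), the highest of the two numbers in hand. Compound 1 `c1ccc(C(OCCC2CCN(Cc3cccnc3)CC2)c2ccccc2)cc1` gives 48.6 nM in this assay, and the step of a 3.5-fold higher number from compound 1 to compound 2 (0.55 log units; beyond the scatter) shows that replacing pyridin-3-yl with 1-benzothiophen-2-yl weakened binding. Compound 3 `c1ccc(C(OCCC2CCN(Cc3cccs3)CC2)c2ccccc2)cc1` is not yet measured; it differs from compound 2 by thiophen-2-yl in place of 1-benzothiophen-2-yl on a saturated chain carbon bound to an amine nitrogen in a ring. Among the compounds with values here, the only measured step that bears on this change is the one from compound 1 to compound 2, which moved the number up by a modest amount when the larger bicyclic group entered. Within the data shown here, removing the fused benzene ring is therefore expected to shift the number back downward, though no measured pair shows the thiophene itself. The expected step is a 2.3-fold lower number from compound 2 to compound 3 (0.36 log units; beyond the scatter). Compound 3 is estimated at 75 nM in this assay, with a range from 25 nM to 220 nM.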

Compound 3, half-maximal inhibitory concentration: 59.3 nM
Compound 3: middle estimate off by 1.3-fold (0.10 log units), on the high side; measured number inside the range.
By their numbers in this assay, from the lowest: compounds 1 and 3 (each within the scatter of the next); then compound 2.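

At this place, on a saturated chain carbon bound to an amine nitrogen in a ring, thiophen-2-yl in place of 1-benzothiophen-2-yl gives a 2.9-fold lower number from compound 2 to compound 3 (0.46 log units; beyond the scatter) in this assay and so ties the higher number of compound 2 to the six-membered aromatic ring of carbon only, not to the five-membered ring that compound 3 keeps. The other new comparison, a 1.2-fold higher number from compound 1 to compound 3 (0.09 log units; within the scatter) and so within the scatter, means that thiophen-2-yl and pyridin-3-yl cannot be told apart here. Nothing at hand explains either step.

As far as these compounds go, whether phenyl or furan-2-yl at this place would also stay close to compound 1 and compound 3 remains open. So does the outcome of a longer chain carrying the thiophen-2-yl group.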